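The source may hold more compounds than are shown below. What is called first, only, known or untested is meant among the compounds shown, and "the series" means these compounds.

Measured so far:
compound 1, `CCCOC(=O)C1=C(C)NC(=O)NC1c1cccs1`, 43%
compound 2, `CCC(C)OC(=O)C1=C(C)NC(=O)NC1c1cccs1`, 5%
compound 3, `CCC(CC)OC(=O)C1=C(C)NC(=O)NC1c1ccsc1`, 22%

All three numbers come from an assay on membranes from CHO cells for displacement of a labelled ligand from adenosine receptor A1 (Homo sapiens), read by scintillation counting, with a stated time of 60 min, tested at 1 uM; on this read-out higher numbers stand for more inhibition at the one concentration tested (going by the name of the read-out) and lower numbers for less inhibition. Within this set compound 1 gives the highest number and compound 2 the lowest; compound 3 stands between them, beyond the scatter from either.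

Compound 4, `CCC(C)OC(=O)C1=C(C)NC(=O)NC1c1ccsc1`, has not been measured. It differs from compound 3 by hydrogen in place of methyl on a saturated chain carbon, two bonds along the chain from an oxygen next to a carbonyl group. The same kind of change is seen between the measured compounds 2 and 1, where the difference is hydrogen in place of methyl on a saturated chain carbon bound to an oxygen next to a carbonyl group and a saturated chain carbon, and there the step was a number 38 percentage points higher from compound 2 to compound 1 (beyond the scatter). The two places are not identical: in the earlier pair the carbon losing the methyl is bound to the oxygen itself, whereas in compound 3 it sits two bonds along the chain from that oxygen. Compound 3 and compound 2 also differ in their cores, and that difference between the two cores is not broken down here; only their values, with compound 3 above compound 2, are known.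

Going by the values given here, the single earlier step points upward, but its place is not the same, so only a smaller gain is expected, a number 10 percentage points higher from compound 3 to compound 4 (within the scatter), and the range is kept wide. Compound 4 is expected to give about 32%, between 10% and 55%.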

Compound 4, a percentage reported as inhibition, at one concentration (the size of the read-out at that concentration, not a potency): 5%
Compound 4: middle estimate off by 27 percentage points, on the high side; measured number below the stated range.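

In this assay, cutting pentan-3-yl to sec-butyl gives a number 17 percentage points lower from compound 3 to compound 4 (beyond the scatter), so hydrogen in place of methyl does not keep one direction across this series: the same change on two cores in this assay, a number 38 percentage points higher (beyond the scatter) from compound 2 to compound 1 and a number 17 percentage points lower (beyond the scatter) from compound 3 to compound 4, 55 percentage points apart, beyond the scatter of two such steps

With sec-butyl held constant, thiophen-3-yl in place of thiophen-2-yl gives no change at the digits printed from compound 2 to compound 4 (within the scatter), so this pair shows no separate effect of the thiophene change. The data do not show whether the opposite directions follow from the core or from the place of the methyl, as the two steps differ in both and each rests on a single pair.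

Open, on these data alone, is how a straight propyl chain reads with thiophen-3-yl, a comparison that would set the place of the methyl apart from the core. Also open, as far as these compounds go, is whether a longer chain such as hexyl, or a cyclopentyl group, in place of sec-butyl would follow either step.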